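Longer Chain on an Ethoxy Core: An Expected Gain

The source may hold more compounds than are shown below. What is called first, only, known or untested is meant among the compounds shown, and "the series" means these compounds.

Three compounds have been measured in a functional assay on NCI-H460 cells (Homo sapiens) for cytotoxicity; a higher number here means a weaker inhibitor, a lower number a stronger inhibitor:

- compound 1, `Cc1ccc2nc(NC(=O)CCCCCCC(=O)NO)sc2c1`, gives 0.84 ug/mL
- compound 2, `Cc1ccc2nc(NC(=O)CCCCC(=O)NO)sc2c1`, gives 11 ug/mL
- compound 3, `CCOc1ccc2nc(NC(=O)CCCCC(=O)NO)sc2c1`, gives 7.96 ug/mL

All three share a core that carries a chain ending in a hydroxamic acid group, and they differ in two places only. Compound 3 differs from compound 2 in the core, by ethoxy in place of methyl on an aromatic carbon. That change made a small step, a 1.4-fold lower number from compound 2 to compound 3 (0.14 log units; within the scatter), so the two cores behave alike in this assay as far as these two compounds show.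

Compound 1 differs from compound 2 by 2-(hydroxycarbamoyl)ethyl in place of hydroxycarbamoyl on a saturated chain carbon, four bonds along the chain from a carbonyl carbon. This change to a longer chain made a large step, a 13-fold lower number from compound 2 to compound 1 (1.12 log units; beyond the scatter).

Compound 4, `CCOc1ccc2nc(NC(=O)CCCCCCC(=O)NO)sc2c1`, has not yet been measured. It differs from compound 3 by 2-(hydroxycarbamoyl)ethyl in place of hydroxycarbamoyl on a saturated chain carbon, four bonds along the chain from a carbonyl carbon. Among the compounds with values here, this is the same change that was made from compound 2 to compound 1, at the same place on the chain; only the core differs, and that difference is the one described between compound 2 and compound 3.

For compound 4 the step expected in this assay is an 11-fold lower number from compound 3 to compound 4 (1.06 log units; beyond the scatter), close to the earlier one, because the same change gave a 13-fold lower number from compound 2 to compound 1 (1.12 log units; beyond the scatter) and because the core difference gave only a 1.4-fold lower number from compound 2 to compound 3 (0.14 log units; within the scatter). On that basis compound 4 is estimated at 0.7 ug/mL, expected to fall between 0.3 ug/mL and 2 ug/mL.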

Compound 4, half-maximal inhibitory concentration: 6.58 ug/mL
Estimate against measurement, compound 4: 9.4-fold (0.97 log units) below, outside the stated range (above it).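

In this assay, the gain from the longer chain did not carry over to the ethoxy-bearing core, where the same change gave only a 1.2-fold lower number from compound 3 to compound 4 (0.08 log units; within the scatter), and the two steps clearly differ: the same change on two cores in this assay, a 13-fold lower number (1.12 log units; beyond the scatter) from compound 2 to compound 1 and a 1.2-fold lower number (0.08 log units; within the scatter) from compound 3 to compound 4, 11-fold (1.03 log units) apart, beyond the scatter of two such steps

Seen from the other side, ethoxy in place of methyl hardly mattered on the shorter chain but gave a 7.8-fold higher number from compound 1 to compound 4 (0.89 log units; beyond the scatter) on the longer one, and these two steps also differ: the same change on two cores in this assay, a 1.4-fold lower number (0.14 log units; within the scatter) from compound 2 to compound 3 and a 7.8-fold higher number (0.89 log units; beyond the scatter) from compound 1 to compound 4, 11-fold (1.03 log units) apart, beyond the scatter of two such steps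

In these four compounds, then, the size of the chain step depends on the core that carries it, so a step measured on one core cannot simply be added to another; however, this rests on a single pair of compounds on each core and does not show why the two cores part ways.

On these data alone, what a still longer chain would do on each core remains open, as does whether the large step on the methyl-bearing core or the flat one on the ethoxy-bearing core is the more common result. A methoxy group or a chlorine atom in place of ethoxy, paired with both chains, could show which of these two cores is the exception.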